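This account rests on a few compounds, and the source may have more. Where it says the series, first, only, none or still open, it means among the compounds named here.

Of the compounds shown here, three have been measured in a functional assay on A549 cells (Homo sapiens) for antiproliferative activity, read by MTT assay, with a stated time of 96 h (a lower number here means a stronger inhibitor of growth, a higher number a weaker inhibitor of growth), so far. Compound 1, `CCc1cc(-c2ccc(F)cc2)nn1Cc1ccc(C(=O)NO)cc1`, gives 19200 nM. Compound 2, `O=C(CCCCCNC(=O)c1cc(-c2ccc(F)cc2)[nH]n1)NO`, gives 7090 nM. Compound 3, `O=C(NO)c1ccc(CNC(=O)c2cc(-c3ccc(F)cc3)[nH]n2)cc1`, gives 20200 nM. Of these three numbers, compound 2 has the lowest, and its gap to compound 1 and its gap to compound 3 both lie beyond the usual scatter, so compound 2 is the strongest inhibitor of growth among them.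

Compound 4, `O=C(CCCCCCNC(=O)c1cc(-c2ccc(F)cc2)[nH]n1)NO`, is the next compound to be measured in this assay. It differs from compound 2 in one place only: (hydroxycarbamoyl)methyl in place of hydroxycarbamoyl on a saturated chain carbon, five bonds along the chain from an amide-type nitrogen. In plain terms, the chain that carries the hydroxycarbamoyl group is lengthened by one saturated carbon.

For the measured compounds named here, no measured pair in this set shows what such a lengthening does, so the expectation rests on compound 2 alone. The change is small, and a modest shift toward stronger inhibition, or none beyond the scatter, is expected. Compound 4 is therefore estimated to give 4000 nM in this assay, with a range from 1500 nM to 11000 nM, a step of a 1.8-fold lower number from compound 2 to compound 4 (0.25 log units; within the scatter) expected from the value of compound 2.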

Compound 4, concentration for 50% growth inhibition: 1980 nM
Compound 4: middle estimate off by 2.0-fold (0.31 log units), on the high side; low and high end bracket the measured number.
By their numbers in this assay, from the lowest: compound 4; then compound 2; then compounds 1 and 3 (each within the scatter of the next).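

In this assay the step is a 3.6-fold lower number from compound 2 to compound 4 (0.55 log units; beyond the scatter) when the chain carrying the hydroxycarbamoyl group is lengthened by one saturated carbon. For the compounds shown here, no earlier pair differed in one place only, so this is the first direct sign that the length of this chain alone can change growth inhibition beyond the usual scatter. No measurement shown explains why the added carbon has this effect.

With only these two chain lengths compared, a longer chain could lower the number further, leave it unchanged or raise it again. Going by these compounds, it also remains open whether a carboxylic acid in place of the hydroxycarbamoyl group at the end of this chain would retain any growth inhibition.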